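The compounds below may be only part of what the source reports. "The series", "measured", "known", "first", "only" and "open" are said of these compounds alone.

Compound 1 `O=C(O)CC[C@H]1CCc2cc(-c3cc(OC(F)(F)F)cc(Cl)c3F)ccc2O1` gives 2200 nM in a functional assay on HEK293 cells for agonist activity at Free fatty acid receptor 1 (Homo sapiens), read by HTRF and inositol phosphate accumulation, with a stated time of 60 min; on this read-out higher numbers stand for an effect only at larger amounts of compound and lower numbers for an effect already at smaller amounts. Compound 2 `Fc1ccc(OC(F)(F)F)cc1-c1ccc2c(c1)CC[C@H](CCc1nnn[nH]1)O2` returns only the assay limit, > 10000 nM. Compound 3 `O=C(O)[C@H]1C[C@@H]1[C@H]1CCc2cc(-c3cc(OC(F)(F)F)ccc3F)ccc2O1` likewise returns only the assay limit, > 10000 nM.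

Compound 3 therefore stands at the limit in this assay, where compound 2 also sits, so the step that the two limits leave unreadable from compound 2 to compound 3 stays unreadable because both values rest at the limit of > 10000 nM in this assay, at which 2 of the 3 values shown sit. Compound 4 `O=C(O)CC[C@H]1CCc2cc(-c3cc(OC(F)(F)F)ccc3F)ccc2O1` differs from compound 3 by 2-carboxyethyl in place of 2-carboxycyclopropyl on a saturated ring carbon. For the measured compounds named here, no measured step covers this exact change; the only compound with a number, compound 1, carries the same 2-carboxyethyl. Compound 4 is expected near 6000 nM, with a range of 2000 nM to 20000 nM. The implied step from compound 3 is estimated as an at least 1.6-fold lower number from compound 3 to compound 4 (0.22 log units; that floor lies within the scatter), with a real chance that only a limit is reported.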

Compound 4, half-maximal effective concentration: 2100 nM
Estimate against measurement, compound 4: 2.9-fold (0.46 log units) above, and the stated range covers the measured number.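

Among the compounds shown, the open 2-carboxyethyl chain is the one that gives a number at this saturated ring carbon: replacing 2-carboxycyclopropyl gives an at least 4.7-fold lower number from compound 3 to compound 4 (0.67 log units; beyond the scatter). On the same chain, carboxy in place of 1H-tetrazol-5-yl gives an at least 4.7-fold lower number from compound 2 to compound 4 (0.67 log units; beyond the scatter). Hydrogen in place of chloro on an aromatic carbon gives a 1.0-fold lower number from compound 1 to compound 4 (0.02 log units; within the scatter), so this pair shows no readable effect of that change.

As far as these compounds go, the full size of the first two steps stays open: the limit of > 10000 nM in this assay, at which 2 of the 4 values shown sit. Also open, from the compounds shown here alone, is how a shorter carboxymethyl chain or a longer 3-carboxypropyl chain would read at this position.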